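Swapping the pyridinyl of compound 3 for a cyclopropyl

The compounds below may be only part of what the source reports. "The series", "measured", "known", "first", "only" and "open" are said of these compounds alone.

Of the compounds shown here, three sharing one core have been measured in an assay on HEK293 cells for inhibition of kynurenine 3-monooxygenase (Homo sapiens), read by LC-MS, with a stated time of 20 h; a lower number here means a stronger inhibitor, a higher number a weaker inhibitor. Compound 1 `COCCOc1cc2oc(=O)n(CCC(=O)O)c2cc1Cl` gives 50100 nM, compound 2 `C[C@@H](Oc1cc2oc(=O)n(CCC(=O)O)c2cc1Cl)c1cccnn1` gives 631 nM, and compound 3 `O=C(O)CCn1c(=O)oc2cc(OCc3ccccn3)c(Cl)cc21` gives 5010 nM. Compound 3 therefore stands second highest of the three: compound 3 is separated from compound 2 by a 7.9-fold higher number from compound 2 to compound 3 (0.90 log units; beyond the scatter), and from compound 1 by a 10-fold lower number from compound 1 to compound 3 (1.00 log units; beyond the scatter).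

Compound 4 `O=C(O)CCn1c(=O)oc2cc(OCC3CC3)c(Cl)cc21` differs from compound 3 by cyclopropyl in place of pyridin-2-yl on a saturated chain carbon bound to an oxygen on an aromatic ring. The step that bears most directly on it is the one in which an aromatic ring replaced a chain, a 10-fold lower number from compound 1 to compound 3 (1.00 log units; beyond the scatter), a modest gain on entering pyridin-2-yl. The larger gain, a 79-fold lower number from compound 1 to compound 2 (1.90 log units; beyond the scatter), likewise came with a ring containing two nitrogens. Compound 4 moves back toward a group without an aromatic ring, so the number for compound 4 in this assay is expected to rise beyond the scatter, though not necessarily to the level of compound 1, since cyclopropyl is a ring. The step from compound 3 to compound 4 is estimated as a 3.0-fold higher number from compound 3 to compound 4 (0.48 log units; beyond the scatter), and compound 4 is expected to give 15000 nM in this assay, within a range from 4000 nM to 60000 nM.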

Compound 4, half-maximal inhibitory concentration: 1580 nM
The estimate for compound 4 lay 9.5-fold (0.98 log units) above the measured number, and the stated range ends above it.
By their numbers in this assay, from the lowest: compound 2; then compound 4; then compound 3; then compound 1.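

The result shows that an aromatic ring is not needed at this place: in this assay, cyclopropyl, a ring of carbon only with no hydrogen-bond acceptor, gives a 3.2-fold lower number from compound 3 to compound 4 (0.50 log units; beyond the scatter) when it replaces pyridin-2-yl. Measured against methoxymethyl, the same place gives a 32-fold lower number from compound 1 to compound 4 (1.50 log units; beyond the scatter), so a non-aromatic ring can exceed the gain seen with pyridin-2-yl. Compound 2 still keeps the lower number, with a 2.5-fold higher number from compound 2 to compound 4 (0.40 log units; beyond the scatter), but that step replaces the whole group on the oxygen and does not isolate any one feature. Nothing available accounts for this order of the groups.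

The compounds shown leave open how phenyl or cyclohexyl would compare with cyclopropyl on the same saturated chain carbon. They also leave open whether a methyl group on that carbon would change the number for the cyclopropyl compound.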